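Linker swap at the chain carbon: compound 3 to compound 4

A few compounds are considered here, and "the series" means these few. Any claim that something is new, unique, unknown or untested is made for them only; others in the source may bear on it.

Measured in an assay for inhibition of Thromboxane-A synthase (Homo sapiens), using microsomes; on this read-out higher numbers stand for weaker inhibition and lower numbers for stronger inhibition:
compound 1 `CC(C)(Oc1ccccc1O)C1OCC(C/C=C\CCC(=O)O)C(c2cccnc2)O1` gives 32 nM;
compound 2 `CC(C)(Oc1ccc(F)cc1[N+](=O)[O-])C1OCC(C/C=C\CCC(=O)O)C(c2cccnc2)O1` gives 20 nM;
compound 3 `CC(C)(Sc1ccccc1)C1OCC(C/C=C\CCC(=O)O)C(c2cccnc2)O1` gives 40 nM.

All three share the core of compound 1 and differ only in the group on the saturated chain carbon bound to two saturated chain carbons and a saturated ring carbon. The steps of a 1.3-fold higher number from compound 1 to compound 3 (0.10 log units; within the scatter) and a 2.0-fold higher number from compound 2 to compound 3 (0.30 log units; within the scatter) both stay within the scatter, as does a 1.6-fold lower number from compound 1 to compound 2 (0.20 log units; within the scatter), so compound 3 sits level with compound 1 and compound 2 on these numbers.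

Compound 4 `CC(C)(Cc1ccc(F)cc1)C1OCC(C/C=C\CCC(=O)O)C(c2cccnc2)O1` continues the same exchange: 4-fluorobenzyl in place of phenylsulfanyl on a saturated chain carbon bound to two saturated chain carbons and a saturated ring carbon. For the measured compounds named here, the two steps that bear on it, from compound 1 to compound 3 and from compound 2 to compound 3, were both within the scatter, and no measured step at this position has moved the numbers beyond it. Compound 4 is therefore expected to give about 35 nM, in the range 15 nM to 85 nM. The expected step of a 1.1-fold lower number from compound 3 to compound 4 (0.06 log units; within the scatter) is estimated to lie within the scatter, in no clear direction.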

Compound 4, half-maximal inhibitory concentration: 45 nM
Compound 4: the middle estimate sits 1.3-fold (0.11 log units) below what was measured; the measured number falls inside the stated range.
By their numbers in this assay, from the lowest: compounds 2, 1, 3 and 4 (each within the scatter of the next, the first and the last beyond it).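

In this assay, the 4-fluorobenzyl group, with no hydrogen-bond acceptor, stays level with phenylsulfanyl (a 1.1-fold higher number from compound 3 to compound 4 (0.05 log units; within the scatter)) and with 2-hydroxyphenoxy (a 1.4-fold higher number from compound 1 to compound 4 (0.15 log units; within the scatter)). For the compounds shown here, the exchange against the group of compound 2 gives the first step at this position beyond the scatter, though only a modest one (a 2.3-fold higher number from compound 2 to compound 4 (0.35 log units; beyond the scatter)).

Going by these compounds, whether an amine on the aromatic ring, or a longer chain joining that ring to the saturated chain carbon, would hold the number in this range stays open. No measurement here accounts for the size of any of these steps.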